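The source may report more compounds than this note shows. Statements on the series, on what has been measured and on what is new or still open speak of the compounds shown alone.

The measured compounds:
Compound 1 `CCCCc1ccc2[nH]c(-c3ccc(OC)cc3)c(/C=N/O)c2c1` gives 212 nM in a functional assay on MCF7 cells (Homo sapiens) for antiproliferative activity, with a stated time of 5 days; a lower number here means a stronger inhibitor, a higher number a weaker inhibitor.
Compound 2 `CCCCc1ccc2[nH]c(-c3ccc(OC)cc3)c(/C=N/NC(=O)c3ccccc3)c2c1` gives 130 nM in this assay.
Compound 3 `CCCCc1ccc2[nH]c(-c3ccc(OC)cc3)c(/C=N/NC(=O)c3ccc(Cl)cc3)c2c1` gives 220 nM in this assay.

All three share one core and differ only in the group attached to the double-bonded nitrogen. Compound 3 carries the highest number of the three, but both neighbours sit close to it: a 1.0-fold higher number from compound 1 to compound 3 (0.02 log units; within the scatter) and a 1.7-fold higher number from compound 2 to compound 3 (0.23 log units; within the scatter). The three compounds therefore cannot be told apart from one another in this assay.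

Compound 4 `CCCCc1ccc2[nH]c(-c3ccc(OC)cc3)c(/C=N/NC(=O)c3ccc(F)cc3)c2c1` differs from compound 3 in one place: fluoro in place of chloro on an aromatic carbon. Among the measured compounds shown here, no measured pair exchanges one halogen for another, so the nearest guide is the step that introduced the chloro: a 1.7-fold higher number from compound 2 to compound 3 (0.23 log units; within the scatter). Since a hydrogen and a chloro in this place gave numbers within the scatter of each other, a fluoro in the same place is expected to leave the number roughly where it stands. No step beyond the scatter is therefore expected in this assay for the move to compound 4. Compound 4 is expected to give 180 nM in this assay, with a range from 90 nM to 360 nM. The expected step is a 1.2-fold lower number from compound 3 to compound 4 (0.09 log units; within the scatter).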

Compound 4, half-maximal inhibitory concentration: 84 nM
For compound 4 the middle estimate is 2.1-fold (0.33 log units) above the measured one, outside the stated range (below it).
By their numbers in this assay, from the lowest: compounds 4, 2, 1 and 3 (each within the scatter of the next, the first and the last beyond it).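

In this assay, among the compounds shown here, exchanging one halogen for another on this aromatic carbon, para to a large group, gives a step that clears the scatter (a 2.6-fold lower number from compound 3 to compound 4 (0.42 log units; beyond the scatter)), which no earlier pair of compounds did. Replacing hydroxy with ((4-fluorophenyl)carbonyl)amino also clears it (a 2.5-fold lower number from compound 1 to compound 4 (0.40 log units; beyond the scatter)), while the benzamido group of compound 2 and the ((4-chlorophenyl)carbonyl)amino group of compound 3 do not, so this gain over the hydroxy compound holds for the fluoro member alone. Hydrogen in this place remains within the scatter of the fluoro (a 1.5-fold lower number from compound 2 to compound 4 (0.19 log units; within the scatter)) as well as of the chloro, so the two halogens can be told apart while neither can be told apart from hydrogen, and nothing measured here offers a reason for the gap.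

With only hydrogen, fluoro and chloro in this place, the compounds shown leave open how a bromo, a methyl or a methoxy group would read there. They also leave open whether the number of compound 4 would hold if the chain on the shared core gave way to a longer chain or a carboxylic acid.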